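The source may report more compounds than this note shows. Statements on the series, on what has been measured and on what is new or still open speak of the compounds shown alone.

Measured compounds:
Compound 1, `N#CN/C(=N\CCCNc1ccc(N=[N+]=[N-])cc1[N+](=O)[O-])NCCCCOc1cccc(CN2CCCCC2)c1`, in a functional assay on cardiac atrium for antagonist activity at histamine H2 receptor (Cavia porcellus) (a higher number here means a more potent compound, by a factor of ten per unit of this negative logarithm, a lower number a less potent compound), gives 6.56.
Compound 2, `N#CN/C(=N\CCNC(=O)c1ccccc1[N+](=O)[O-])NCCCCOc1cccc(CN2CCCCC2)c1`, in this assay gives 7.52.

Compound 2 has the higher of the two numbers shown. Compound 1 stands lower, and the gap between them is beyond the scatter, so compound 2 is the more potent of these two. The two compounds are not a single-change pair, so nothing more is read from the gap than the two values themselves.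

Compound 3, `Cc1ccc(S(=O)(=O)NCC/N=C(\NC#N)NCCCCOc2cccc(CN3CCCCC3)c2)cc1`, keeps the shared core of compound 2 and changes one group: (4-methylphenyl)sulfonyl in place of (2-nitrophenyl)carbonyl on an amine nitrogen. The amide carbonyl of compound 2 is thus replaced by a sulfonyl link carrying a methyl-substituted ring, and the nitro group is gone. Among the measured compounds shown here, no measured pair shows a change of this kind, so the size of the step is not known from the data. In this assay the step from compound 2 to compound 3 is expected to be small and downward, a number 0.32 log units lower from compound 2 to compound 3 (beyond the scatter), close to the edge of the scatter. Compound 3 is therefore expected at 7.2, within a range from 6.5 to 7.9.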

Compound 3, negative logarithm of the antagonist equilibrium constant: 7.29
Compound 3: middle estimate off by 0.09 log units, on the low side; measured number inside the range.
By their numbers in this assay, from the lowest: compound 1; then compounds 3 and 2 (each within the scatter of the next).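

In this assay, putting (4-methylphenyl)sulfonyl in place of (2-nitrophenyl)carbonyl on an amine nitrogen gives a number 0.23 log units lower from compound 2 to compound 3 (within the scatter), so this position takes a quite different group with no change that can be told from the usual scatter. The swap alters the link and the ring substituent together, so a flat result here could mean that neither part matters or that two opposite contributions cancel, and this pair cannot tell those readings apart. No measurement of any other property bears on this result.

As far as these compounds go, it remains open whether a sulfonyl link carrying a plain phenyl ring, with neither methyl nor nitro, would stay at this level, which would separate the effect of the link from that of the ring substituent. From the compounds shown here alone, it is also open how far this tolerance reaches for groups of another kind, such as an amine or a carboxylic acid on the ring, or a longer chain leading to the amine nitrogen.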